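This account rests on a few compounds, and the source may have more. Where it says the series, first, only, none or still open, it means among the compounds named here.

Among the measured compounds shown here, compound 2 `COc1cc(C(=O)c2sc(-c3ccc(F)cc3)cc2N)cc(OC)c1OC` gives the lowest of the two numbers so far in a functional assay on CCRF-CEM cells (Homo sapiens) for antiproliferative activity; a lower number here means a stronger inhibitor, a higher number a weaker inhibitor: compound 2 gives 15 nM, whereas compound 1 `COc1cc(C(=O)c2sc(-c3ccc(Cl)cc3)cc2N)cc(OC)c1OC` gives 70 nM. For the measured compounds named here, the single measured step, a 4.7-fold lower number from compound 1 to compound 2 (0.67 log units; beyond the scatter), came from fluoro in place of chloro on an aromatic carbon and is the only guide available. Compound 3 `COc1cccc(-c2cc(N)c(C(=O)c3cc(OC)c(OC)c(OC)c3)s2)c1` carries a different change: 3-methoxyphenyl in place of 4-fluorophenyl on an aromatic carbon. Going by the values given here, no measured step concerns a 3-methoxyphenyl group, so the halogen step bears on compound 3 only loosely, by showing that the group at this position on the shared core shifts the number beyond the scatter. Because that shift a 4.7-fold lower number from compound 1 to compound 2 (0.67 log units; beyond the scatter) was modest, compound 3 is expected to stay within a modest distance of compound 2, with the direction uncertain but more likely a weaker inhibitor. The estimated step is a 2.7-fold higher number from compound 2 to compound 3 (0.43 log units; beyond the scatter). Compound 3 is therefore estimated at 40 nM, in a range from 10 nM to 160 nM.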

Compound 3, half-maximal inhibitory concentration: 16 nM
For compound 3 the middle estimate is 2.5-fold (0.40 log units) above the measured one; measured number inside the range.
By their numbers in this assay, from the lowest: compounds 2 and 3 (each within the scatter of the next); then compound 1.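

At the aromatic carbon next to the ring sulfur, 3-methoxyphenyl in place of 4-fluorophenyl gives a 1.1-fold higher number from compound 2 to compound 3 (0.03 log units; within the scatter) in this assay, so these two groups cannot be told apart here, although they differ in the substituent and in the hydrogen-bond acceptor that enters with the methoxy oxygen. Replacing 4-chlorophenyl with 3-methoxyphenyl gives a 4.4-fold lower number from compound 1 to compound 3 (0.64 log units; beyond the scatter), which leaves compound 1 alone apart from the other two and shows that a halogen on the phenyl ring is not required for a number in the range of compound 2. No evidence is available to explain these results.

On these data alone, what 4-methoxyphenyl would give at this position, and whether the place of the methoxy group on the phenyl ring matters, stays open. As far as these compounds go, it is also open how an amine or a carboxylic acid on that phenyl ring would fare.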